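Chloro for Bromo on a Shared Core

The source may report more compounds than this note shows. Statements on the series, on what has been measured and on what is new or still open speak of the compounds shown alone.

Of the compounds shown here, three built on one shared core have been tested in a functional assay on MCF7 cells (Homo sapiens) for cytotoxicity, read by sulforhodamine B assay, with a stated time of 48 h; on this read-out higher numbers stand for weaker inhibition of growth and lower numbers for stronger inhibition of growth. Compound 1 `Cc1ccc2nc(/N=C3\C(=O)N(CN(C)C)c4cccc(Br)c43)sc2c1` gives 18000 nM. Compound 2 `O=C1C(=O)N(CN(c2ccccc2)c2ccccc2)c2cccc(Br)c21` gives 110000 nM. Compound 3 `Cc1ccc2nc(/N=C3\C(=O)N(CN4CCCCC4)c4cccc(Br)c43)sc2c1` gives 39100 nM, the second highest of the three numbers, with compound 1 nearest to it and compound 2 furthest away. For the measured compounds named here, the only step measured between two compounds differing in one place, a 2.2-fold higher number from compound 1 to compound 3 (0.34 log units; beyond the scatter), concerns the group on the saturated chain carbon and not the halogen on the aromatic ring. Compound 4 `Cc1ccc2nc(/N=C3\C(=O)N(CN4CCCCC4)c4cccc(Cl)c43)sc2c1` differs from compound 3 by chloro in place of bromo on an aromatic carbon. Going by the values given here, no measured step bears directly on this exchange, so only a small shift is expected, a 1.2-fold higher number from compound 3 to compound 4 (0.06 log units; within the scatter). Compound 4 is therefore expected to give about 45000 nM, within a range from 18000 nM to 110000 nM.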

Compound 4, concentration for 50% growth inhibition: 30900 nM
Compound 4: the middle estimate sits 1.5-fold (0.16 log units) above what was measured; measured number inside the range.
By their numbers in this assay, from the lowest: compounds 1, 4 and 3 (each within the scatter of the next, the first and the last beyond it); then compound 2.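

For the compounds shown here, this is the first measured exchange of the halogen on the aromatic ring of the shared core. Chloro in place of bromo gives a 1.3-fold lower number from compound 3 to compound 4 (0.10 log units; within the scatter) in this assay and stays within the scatter, so with piperidin-1-yl on the chain the two halogens cannot be told apart at this position. Nothing measured here offers a reason for this.

Still open, as far as these compounds go, is whether fluoro, methyl or methoxy on this same aromatic carbon would also leave the number within the scatter. Also open, from the compounds shown here alone, is whether chloro for bromo reads the same with dimethylamino in place of piperidin-1-yl.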